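Replacing thiophen-3-yl with 2-hydroxyphenyl

The compounds below may be only part of what the source reports. "The series", "measured", "known", "first", "only" and "open" are said of these compounds alone.

In a functional assay on HeLa cells (Homo sapiens) for inhibition, with a stated time of 72 h (on this read-out higher numbers stand for weaker inhibition and lower numbers for stronger inhibition), compound 1 `NC1CCC(Nc2nc(NCc3ccc(-c4cccc(F)c4)nc3)c3ncn(C4CCCC4)c3n2)CC1` gives 36 nM, compound 2 `NC1CCC(Nc2nc(NCc3ccc(-c4ccco4)nc3)c3ncn(C4CCCC4)c3n2)CC1` gives 30 nM and compound 3 `NC1CCC(Nc2nc(NCc3ccc(-c4ccsc4)nc3)c3ncn(C4CCCC4)c3n2)CC1` gives 75 nM, the highest number of the three. These compounds differ only in one aromatic group on the shared core. Changing that group has moved the number little so far: a 1.2-fold lower number from compound 1 to compound 2 (0.08 log units; within the scatter), while the steps to thiophen-3-yl are modest, a 2.1-fold higher number from compound 1 to compound 3 (0.32 log units; beyond the scatter) and a 2.5-fold higher number from compound 2 to compound 3 (0.40 log units; beyond the scatter). Compound 4 `NC1CCC(Nc2nc(NCc3ccc(-c4ccccc4O)nc3)c3ncn(C4CCCC4)c3n2)CC1` carries 2-hydroxyphenyl in place of thiophen-3-yl (2-hydroxyphenyl in place of thiophen-3-yl on an aromatic carbon). Going by the values given here, no measured compound carries this group, so the guide is loose. A small expected step toward a lower number, a 1.7-fold lower number from compound 3 to compound 4 (0.22 log units; within the scatter), would reverse the modest steps above. Compound 4 is estimated at 45 nM, within an expected range of 15 nM to 130 nM.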

Compound 4, half-maximal inhibitory concentration: 16 nM
Estimate against measurement, compound 4: 2.8-fold (0.45 log units) above; measured number inside the range.
By their numbers in this assay, from the lowest: compounds 4, 2 and 1 (each within the scatter of the next, the first and the last beyond it); then compound 3.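

With 2-hydroxyphenyl, this position gives its largest step among the compounds shown, a 4.7-fold lower number from compound 3 to compound 4 (0.67 log units; beyond the scatter), and the change also stays beyond the scatter against 3-fluorophenyl, a 2.3-fold lower number from compound 1 to compound 4 (0.35 log units; beyond the scatter). Against furan-2-yl, however, it cannot be told apart, a 1.9-fold lower number from compound 2 to compound 4 (0.27 log units; within the scatter). Nothing available explains these steps. Going by these compounds, whether the hydroxyl group itself matters remains open. A plain phenyl, 2-methoxyphenyl or 2-aminophenyl at this position would help to test that.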